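Chain length between core and tetrazole: compound 2 to compound 3

A few compounds are considered here, and "the series" means these few. Any claim that something is new, unique, unknown or untested is made for them only; others in the source may bear on it.

Among the measured compounds shown here, compound 2 `CCCc1c(CCCCCc2nnn[nH]2)ccc(C(C)=O)c1O` carries the tetrazole on a five-carbon chain and in a functional assay on ileum for antagonist activity at cysteinyl leukotriene receptor 1 (Cavia porcellus) (a lower number here means a less potent compound, a higher number a more potent compound, by a factor of ten per unit of this negative logarithm), compound 2 gives 7.5, the higher of the two numbers measured so far. Compound 1 `CCCc1c(OCCCc2nnn[nH]2)ccc(C(C)=O)c1O`, with the tetrazole on an oxypropyl tether, gives in this assay 5.64, and the gap between these two values lies beyond the usual scatter. For the measured compounds named here, no step between compounds differing in a single place has been measured.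

Compound 3 `CCCc1c(CCCCc2nnn[nH]2)ccc(C(C)=O)c1O` differs from compound 2 by 1H-tetrazol-5-yl in place of (1H-tetrazol-5-yl)methyl on a saturated chain carbon, four bonds along the chain from an aromatic carbon, so the chain to the tetrazole is shortened by one carbon. Nothing measured shows how this assay responds to chain length alone. The expectation for compound 3 is a modest fall in this assay, of about a number 0.50 log units lower from compound 2 to compound 3 (beyond the scatter), while remaining above compound 1. Compound 3 is therefore estimated at 7 in this assay, with a range from 6.3 to 7.6.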

Compound 3, negative logarithm of the antagonist equilibrium constant: 6.67
Beside the measured number, compound 3's estimate is 0.33 log units above it, and the stated range covers the measured number.
By their numbers in this assay, from the lowest: compound 1; then compound 3; then compound 2.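

Shortening the chain gives the series its first single-place step: in this assay, the value falls by a number 0.83 log units lower from compound 2 to compound 3 (beyond the scatter), so this chain responds to a change in length by a single carbon. Both the leaving (1H-tetrazol-5-yl)methyl and the entering 1H-tetrazol-5-yl carry the same counts of hydrogen-bond donors and acceptors, and the two groups differ by one carbon. Nothing available explains why the value moves with chain length.

Among the compounds shown here, with only two chain lengths compared, a single step sets no trend, and whether a longer chain would raise or lower the value remains open. Also open, from the compounds shown here alone, is whether a carboxylic acid at the chain end, in place of the tetrazole, would hold the value of compound 2.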